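The source may hold more compounds than are shown below. What is called first, only, known or untested is meant among the compounds shown, and "the series" means these compounds.

Compound 2, with the structure `COc1cc(N(C)C(=O)N(C)c2cccc([N+](=O)[O-])c2)cc(OC)c1OC`, is built on the same urea core as compound 1, whose structure is `COc1cc(N(C)C(=O)N(C)c2ccc(F)cc2)cc(OC)c1OC`. In a functional assay on Daoy cells (Homo sapiens) for cytotoxicity, read by MTT assay, with a stated time of 72 h (on this read-out higher numbers stand for weaker inhibition and lower numbers for stronger inhibition), compound 2 gives >= 125000 nM, which is a limit of the assay and not a measured number. In this assay compound 1 likewise gives only a limit, >= 125000 nM. Within the data shown here, the one measured step, a step that the two limits leave unreadable from compound 1 to compound 2, is therefore unreadable; all that can be said rests on (the limit of >= 125000 nM in this assay, at which 2 of the 2 values shown sit).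

Compound 3, with the structure `COc1cc(N(C)C(=O)N(C)c2cccc(F)c2)cc(OC)c1OC`, differs from compound 2 by fluoro in place of nitro on an aromatic carbon. Among the measured compounds shown here, no measured step shows how this change alters potency, so the only guide is that every value so far sits at the limit. Compound 3 is thus expected to reach no further than that limit and to show no step beyond the scatter. The estimated step is a number no higher from compound 2 to compound 3 (the limit leaves the size open). For compound 3 the expected value is 125000 nM, with a range from 60000 nM to 250000 nM.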

Compound 3, half-maximal inhibitory concentration: >= 125000 nM
Compound 3: only a limit was reported; the forecaster's own chance of this, stated with the estimate: 80%; the middle value sits exactly at the limit.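

The steps linking compound 3 with compound 1 and compound 2 cannot be read, since all these values are limits of the assay and not numbers: the limit of >= 125000 nM in this assay, at which 3 of the 3 values shown sit.

The compounds shown leave open whether changing this aromatic group can alter potency at all in this assay.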